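A pyridine regioisomer swap on a weakly active indole ketone

The compounds below may be only part of what the source reports. "The series", "measured", "known", "first", "only" and "open" are said of these compounds alone.

Compound 2 `O=C(Cc1ccncc1)c1cc2ccccc2[nH]1` was tested in an assay on isolated protein for inhibition of Indoleamine 2,3-dioxygenase 1 (Homo sapiens), read by spectrophotometry (on this read-out higher numbers stand for weaker inhibition and lower numbers for stronger inhibition), and was reported as "not active" (no number reported), so no single number marks where it stands. The only numerical anchor in this series comes from compound 1 `O=C(Cc1cccnc1)c1cc2c(O)cccc2[nH]1`, which differs from compound 2 in more than one place; in this assay compound 1 gives 83000 nM, a very weak result that sets the general level of potency for this shared core. Compound 3 `O=C(Cc1ccccn1)c1cc2ccccc2[nH]1` has not yet been measured. It differs from compound 2 by a single change: pyridin-2-yl in place of pyridin-4-yl on a saturated chain carbon bound to a carbonyl carbon. Since compound 2 has no measured value, no step size can be computed for this pair; given that compound 2 showed no activity and that compound 1 gives 83000 nM, any movement in this assay is expected to stay close to that weak level, with a direction that cannot be called from the available data. Compound 3 is therefore expected to give about 100000 nM, within a range from 30000 nM to 400000 nM, with a real chance that it is again recorded only as inactive.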

Compound 3, half-maximal inhibitory concentration: 37000 nM
For compound 3 the middle estimate is 2.7-fold (0.43 log units) above the measured one, within the range that was stated.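

Among the compounds shown here, compound 2 was recorded without a number while compound 3 gives 37000 nM, so no step between the two can be read. No supporting evidence bears on this result. The compounds shown leave open how far pyridin-2-yl and pyridin-4-yl differ on the shared core in this assay.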